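The source may report more compounds than this note shows. Statements on the series, on what has been measured and on what is new or still open speak of the compounds shown alone.

Measured compounds:
Compound 1 `Nc1nc(N/N=C/c2cccc(OCc3ccccc3)c2)nc2c1ncn2[C@@H]1O[C@H](CO)[C@@H](O)[C@H]1O` — in an assay on CHO-K1 cells for displacement of a labelled ligand from adenosine receptor A1 (Homo sapiens), read by scintillation counting, with a stated time of 60 min (on this read-out higher numbers stand for weaker inhibition and lower numbers for stronger inhibition), compound 1 gives 13 nM.
Compound 2 `CSCC/C=N/Nc1nc(N)c2ncn([C@@H]3O[C@H](CO)[C@@H](O)[C@H]3O)c2n1` — in this assay compound 2 gives > 10000 nM, which is a limit of the assay and not a number.

Compound 2 therefore stands at the weak end of what this assay can report; of the two values shown, it is the one that sits at the limit of > 10000 nM in this assay, at which 1 of the 2 values shown sits. Among the compounds with values here, compound 1 is the only compound of the pair with an actual number.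

Compound 3 `CN(C)c1ccc(/C=N/Nc2nc(N)c3ncn([C@@H]4O[C@H](CO)[C@@H](O)[C@H]4O)c3n2)cc1` has not yet been measured in this assay. It differs from compound 2 in one place: 4-(dimethylamino)phenyl in place of 2-(methylsulfanyl)ethyl on a carbon with a double bond to nitrogen.

Within the data shown here, no step between measured compounds is available, so the size of the change from compound 2 to compound 3 in this assay cannot be read off directly. The account expects a step toward stronger inhibition, beyond the scatter. Compound 2 sits at a limit of the assay, > 10000 nM. Compound 1, by contrast, reaches 13 nM. The expected step is an at least 160-fold lower number from compound 2 to compound 3 (2.22 log units; beyond the scatter). For compound 3 the estimate in this assay is 60 nM, expected to lie between 10 nM and 600 nM.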

Compound 3, inhibition constant: > 10000 nM
Compound 3: a limit, no number (the forecaster's own chance of this, stated with the estimate: 10%); middle value at least 160-fold (2.22 log units) away from the limit.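

In this assay compound 3 gives > 10000 nM, which is a limit of the assay and not a number. Compound 2 also stands at a limit, so no step can be read between compound 2 and compound 3: the limit of > 10000 nM in this assay, at which 2 of the 3 values shown sit.

The compounds shown leave open how the 4-(dimethylamino)phenyl and 2-(methylsulfanyl)ethyl compounds truly compare, since neither has an actual number.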